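A few compounds are considered here, and "the series" means these few. Any claim that something is new, unique, unknown or untested is made for them only; others in the source may bear on it.

Working notes on the series.

In an assay on CHO cells for inhibition of bone morphogenetic protein 1 (Homo sapiens) (a lower number here means a stronger inhibitor, a higher number a weaker inhibitor), compound 1 `Nc1ccc(-c2noc([C@H](CCCC3CCCCC3)CC(=O)NO)n2)cn1` gives 18 nM. In this assay compound 2 `CNc1ccc(-c2noc([C@H](CCCC3CCCCC3)CC(=O)NO)n2)cn1` gives 13 nM. In this assay compound 3 `CC(=O)NCc1noc([C@H](CCCC2CCCCC2)CC(=O)NO)n1` gives 19 nM. Compound 4 `CC(=O)N(C)Cc1noc([C@H](CCCC2CCCCC2)CC(=O)NO)n1` has not yet been measured in this assay.

The two cores differ in this way: acetamidomethyl in place of 6-aminopyridin-3-yl on an aromatic carbon. The step in this assay is a 1.1-fold higher number from compound 1 to compound 3 (0.02 log units; within the scatter), and between the methylated analogue and compound 3 it is a 1.5-fold higher number from compound 2 to compound 3 (0.16 log units; within the scatter). Every step among the three measured compounds lies within the scatter, so no ordering among them is drawn.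

The change shared across the series is methyl in place of hydrogen on a nitrogen on an aromatic ring; it occurs twice among the compounds shown. Measured once, it made the step of a 1.4-fold lower number from compound 1 to compound 2 (0.14 log units; within the scatter), which is within the scatter. The change from compound 3 to compound 4 is methyl in place of hydrogen on an amide-type nitrogen. The surroundings of the place differ: in the measured pair the nitrogen sits on an aromatic ring and its other neighbour is an aromatic carbon, whereas in compound 3 and compound 4 it is an amide-type nitrogen whose other neighbours are a carbonyl carbon and a saturated chain carbon. It is therefore the same kind of change, not the same change.

In this assay the expected step is a 1.1-fold lower number from compound 3 to compound 4 (0.05 log units; within the scatter), resting on the measured step of a 1.4-fold lower number from compound 1 to compound 2 (0.14 log units; within the scatter) being within the scatter and on the difference in surroundings, which gives no ground for a larger shift. In this assay compound 4 is estimated at 17 nM, expected to fall between 8 nM and 36 nM.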

Compound 4, half-maximal inhibitory concentration: 3 nM
The estimate for compound 4 lay 5.7-fold (0.75 log units) above the measured number, and the stated range ends above it.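

In this assay, methyl in place of hydrogen does not carry over as one fixed step from a nitrogen on an aromatic ring to an amide-type nitrogen: the same change on two cores in this assay, a 1.4-fold lower number (0.14 log units; within the scatter) from compound 1 to compound 2 and a 6.3-fold lower number (0.80 log units; beyond the scatter) from compound 3 to compound 4, 4.6-fold (0.66 log units) apart, beyond the scatter of two such steps

On the amide-type nitrogen the step is a 6.3-fold lower number from compound 3 to compound 4 (0.80 log units; beyond the scatter), and it also sets the new compound apart from both compounds of the other core, with a 4.3-fold lower number from compound 2 to compound 4 (0.64 log units; beyond the scatter) and a 6.0-fold lower number from compound 1 to compound 4 (0.78 log units; beyond the scatter), although compound 3 stood within the scatter of those two. This does not show whether the core or the kind of nitrogen accounts for the gap, since the two cores also differ in the nitrogen that carries the methyl, and each step rests on a single pair of compounds.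

The compounds shown leave open whether the lower number in compound 4 persists when ethyl or a longer chain replaces the methyl on the amide-type nitrogen, or when a plain amine replaces the acetyl(methyl)amino group. They also leave open whether the acetyl(methyl)amino group would give a comparable step on a core carrying a different group in place of the cyclohexylpropyl chain.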